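The source may report more compounds than this note shows. Statements on the series, on what has been measured and on what is new or still open speak of the compounds shown alone.

Three compounds have been measured in an assay on microsomes from intestine for inhibition of acyl-CoA:cholesterol acyltransferase (Oryctolagus cuniculus); on this read-out higher numbers stand for weaker inhibition and lower numbers for stronger inhibition:

compound 1 `CC(C)c1cccc(C(C)C)c1OC(=O)NC(=O)OCc1ccccc1` — 77 nM
compound 2 `CCCCC(C)(C)OC(=O)NC(=O)Oc1c(C(C)C)cccc1C(C)C` — 64 nM
compound 3 `CC(C)c1cccc(C(C)C)c1OC(=O)NC(=O)SCCc1ccccc1` — 880 nM

Compound 3 gives the highest number of the three, that is, the weakest inhibition: the two steps that lead to it are an 11-fold higher number from compound 1 to compound 3 (1.06 log units; beyond the scatter) and a 14-fold higher number from compound 2 to compound 3 (1.14 log units; beyond the scatter). Compound 4 `CC(C)c1cccc(C(C)C)c1OC(=O)NC(=O)SC1CCCCC1` has not yet been measured; it differs from compound 3 in one place: cyclohexyl in place of phenethyl on a sulfur. Among the measured compounds shown here, no measured step touches the group on the sulfur. The nearest guide is the step on the oxygen of compound 1, where a benzyl group is exchanged for a 1,1-dimethylpentyl group: a 1.2-fold lower number from compound 1 to compound 2 (0.08 log units; within the scatter). That exchange of a group with an aromatic ring for one without a ring came with a step within the scatter. The two large steps concern the move from an oxygen-linked group to the sulfur-linked phenethyl, a feature that compound 3 and compound 4 share, so they say nothing about the present change. The expectation for compound 4 is therefore a step of a 1.0-fold higher number from compound 3 to compound 4 (0.01 log units; within the scatter) in this assay. Compound 4 is thus estimated at 900 nM, with a range from 300 nM to 3000 nM.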

Compound 4, half-maximal inhibitory concentration: 97 nM
Compound 4: the middle estimate sits 9.3-fold (0.97 log units) above what was measured; the measured number lies below the stated range.
By their numbers in this assay, from the lowest: compounds 2, 1 and 4 (each within the scatter of the next); then compound 3.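

On the sulfur the group matters: in this assay, cyclohexyl in place of phenethyl gives a 9.1-fold lower number from compound 3 to compound 4 (0.96 log units; beyond the scatter), so a sulfur-linked group on this carbonyl carbon does not by itself go with the weak inhibition of compound 3. Compound 4 also stays level with the two compounds that carry an oxygen at this place, with a 1.3-fold higher number from compound 1 to compound 4 (0.10 log units; within the scatter) and a 1.5-fold higher number from compound 2 to compound 4 (0.18 log units; within the scatter), both within the scatter. Nothing available here explains why the phenethyl group and the cyclohexyl group on the sulfur differ.

This change replaces an aromatic ring with a non-aromatic one and also removes the chain that links the ring to the sulfur, so the two cannot be told apart. A 2-cyclohexylethyl group or a phenyl group on the sulfur would separate them.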